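A few compounds are considered here, and "the series" means these few. Any claim that something is new, unique, unknown or untested is made for them only; others in the source may bear on it.

Measured so far in an ADME assay on MT4 cells (Homo sapiens) for cytotoxicity, with a stated time of 5 days; on this read-out lower numbers stand for higher toxicity in this test and higher numbers for lower toxicity in this test:
- compound 1 `O=C1CN(S(=O)(=O)c2ccccc2F)c2cc(Cl)ccc2N1`: 197000 nM
- compound 2 `O=C1CN(S(=O)(=O)c2cccc(F)c2)c2cc(Cl)ccc2N1`: 189000 nM

In this assay compound 2 gives 189000 nM, and this number cannot be told apart from that of compound 1, since the two lie within the scatter of each other. Not yet measured is compound 3 `O=C1CN(S(=O)(=O)c2ccc(F)cc2)c2cc(Cl)ccc2N1`, which differs from compound 2 as follows: 4-fluorophenyl in place of 3-fluorophenyl on a sulfonyl sulfur. In words, this is 4-fluorophenyl in place of 3-fluorophenyl on a sulfonyl sulfur. For the measured compounds named here, the one measured step of the same kind, 3-fluorophenyl in place of 2-fluorophenyl on a sulfonyl sulfur, is a 1.0-fold lower number from compound 1 to compound 2 (0.02 log units; within the scatter). Two compounds make a thin basis, but on this evidence no step beyond the scatter is expected, in either direction. The expected change is a 1.0-fold higher number from compound 2 to compound 3 (0.00 log units; within the scatter). For compound 3 the estimate in this assay is 190000 nM, with an expected range of 120000 nM to 280000 nM.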

Compound 3, half-maximal cytotoxic concentration: 172000 nM
Beside the measured number, compound 3's estimate is 1.1-fold (0.04 log units) above it; low and high end bracket the measured number.
By their numbers in this assay, from the lowest: compounds 3, 2 and 1 (each within the scatter of the next).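

In this assay, 4-fluorophenyl in place of the other two fluorophenyl groups on the sulfonyl sulfur gives a 1.1-fold lower number from compound 2 to compound 3 (0.04 log units; within the scatter) and a 1.1-fold lower number from compound 1 to compound 3 (0.06 log units; within the scatter). The 2-fluorophenyl, 3-fluorophenyl and 4-fluorophenyl compounds therefore cannot be told apart on this read-out, so within these three compounds the choice among the fluorophenyl isomers carries no measurable difference. Nothing available bears on why the three compounds behave alike.

Still open, as far as these compounds go, is whether a different group on that phenyl ring, such as an amine, a carboxylic acid or a methoxy group, would give a step beyond the scatter. Also open, from the compounds shown here alone, is how replacing the chlorine on the shared core, or the phenyl ring itself with a longer alkyl chain, would read in this assay.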